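Chloro in place of bromo on the shared core

The compounds below may be only part of what the source reports. "The series", "measured", "known", "first", "only" and "open" are said of these compounds alone.

Compound 1 `Brc1ccc(C2=NN(C3=NC(c4ccccc4)CS3)C(c3ccc4ccccc4c3)C2)cc1` — 20300 nM
Compound 2 `Fc1ccc(C2=NN(C3=NC(c4ccccc4)CS3)C(c3cccc4ccccc34)C2)cc1` — 23200 nM
Compound 3 `O=C1CSC(N2N=C(c3ccc(Br)cc3)CC2c2ccc3ccccc3c2)=N1` — 18200 nM

In a functional assay on HepG2 cells (Homo sapiens) for inhibition, read by CCK-8 assay, with a stated time of 48 h (a higher number here means a weaker inhibitor, a lower number a stronger inhibitor), compound 1 gives 20300 nM, the second highest of the three numbers. Among the measured compounds shown here, compound 3 lies nearest, and the single step of a 1.1-fold lower number from compound 1 to compound 3 (0.05 log units; within the scatter) stays within the scatter. Compound 2 lies furthest, yet its number is also within the scatter of compound 1.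

Compound 4 `Clc1ccc(C2=NN(C3=NC(c4ccccc4)CS3)C(c3ccc4ccccc4c3)C2)cc1` differs from compound 1 in one place: chloro in place of bromo on an aromatic carbon. For the measured compounds named here, the one step measured so far, a 1.1-fold lower number from compound 1 to compound 3 (0.05 log units; within the scatter), alters a group on an amine nitrogen in a ring and leaves the halogen untouched, so it does not speak directly to this change. Compound 2 carries a different halogen, but it also differs from compound 1 in how the naphthalene is attached, so only the two values can be compared, and they sit within the scatter of each other. Nothing among the three measured compounds points to a halogen-driven shift.

Compound 4 is therefore expected to give 21000 nM in this assay, within a range of 10000 nM to 45000 nM. The expected step is a 1.0-fold higher number from compound 1 to compound 4 (0.01 log units; within the scatter), that is, none beyond the scatter.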

Compound 4, half-maximal inhibitory concentration: 22100 nM
For compound 4 the middle estimate is 1.1-fold (0.02 log units) below the measured one; the range from low to high includes it.
By their numbers in this assay, from the lowest: compounds 3, 1, 4 and 2 (each within the scatter of the next).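

In this assay, among the compounds shown here, the 4-bromophenyl to 4-chlorophenyl exchange gives a 1.1-fold higher number from compound 1 to compound 4 (0.04 log units; within the scatter), the first reading of a halogen exchange on this aromatic carbon with the rest of the molecule held the same. Compound 2 could not show this, as its fluoro comes together with a different attachment of the naphthalene, and the step to compound 3 concerns the group on the ring nitrogen instead. For this pair, then, bromo and chloro at this position, para to a large group, cannot be told apart in this assay, and no measurement is available to explain the result.

The compounds shown leave open whether a non-halogen group on this aromatic carbon, such as a methoxy, a nitrile or an amine, would give a number beyond the scatter of compound 1. They also leave open whether the same exchange would read alike on the core of compound 2, or with the smaller group on the ring nitrogen that compound 3 carries.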